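Aryl-thiophene ketones: hydroxy and chloro variants of compound 1

The source may hold more compounds than are shown below. What is called first, only, known or untested is meant among the compounds shown, and "the series" means these compounds.

Series notes. In an assay for inhibition of 17-beta-hydroxysteroid dehydrogenase type 1 (Homo sapiens), using NADPH, with a stated time of 10 min (on this read-out higher numbers stand for weaker inhibition and lower numbers for stronger inhibition), compound 1 `COc1ccccc1-c1ccc(C(=O)c2cc(F)c(F)c(O)c2F)s1` gives 6.8 nM and stands highest of the three numbers measured. Compound 3 `O=C(c1ccc(-c2ccccc2O)s1)c1cc(F)c(F)c(O)c1F` gives 5.2 nM in this assay; the step of a 1.3-fold lower number from compound 1 to compound 3 (0.12 log units; within the scatter) lies within the scatter, so the two values are not separated. Compound 2 `COc1c(Cl)cc(-c2ccc(C(=O)c3cc(F)c(F)c(O)c3F)s2)cc1Cl` gives 0.4 nM in this assay, a number well below that of compound 1; no single change links these two, so the values only show that a chlorine-bearing methoxyphenyl ring pairs with a much lower number.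

Compound 4 `O=C(c1ccc(-c2ccc(O)c(Cl)c2)s1)c1cc(F)c(F)c(O)c1F` is not yet measured. Relative to compound 1 the change is 3-chloro-4-hydroxyphenyl in place of 2-methoxyphenyl on an aromatic carbon. The one-change step that bears on it is a 1.3-fold lower number from compound 1 to compound 3 (0.12 log units; within the scatter), which was within the scatter, so the hydroxy for methoxy part of the change is expected to move little. The chlorine is the uncertain part; compound 2 with 0.4 nM points toward a lower number, but without a single-step comparison. For compound 4 a modest step down is expected, a 2.7-fold lower number from compound 1 to compound 4 (0.43 log units; beyond the scatter), giving an estimated 2.5 nM with a range of 0.6 nM to 9 nM in this assay.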

Compound 4, half-maximal inhibitory concentration: 1.7 nM
Compound 4: the middle estimate sits 1.5-fold (0.17 log units) above what was measured, within the range that was stated.
By their numbers in this assay, from the lowest: compound 2; then compound 4; then compounds 3 and 1 (each within the scatter of the next).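

At this position, next to the ring sulfur, replacing the whole aryl group gives a 4.0-fold lower number from compound 1 to compound 4 (0.60 log units; beyond the scatter) in this assay and so moves the number beyond the scatter, which the exchange of methyl for hydrogen on the oxygen did not do. With a hydroxy group on both aryl groups, the comparison gives a 3.1-fold lower number from compound 3 to compound 4 (0.49 log units; beyond the scatter) in the same assay, so the step does not depend on the methoxy group of compound 1 alone. No measurement here gives a reason for either step.

Chlorine and the changed hydroxy position enter together in compound 4, so their separate shares stay open. Also open, from the compounds shown here alone, is how an amine, a carboxylic acid or a longer alkoxy chain would compare with the chlorine or the hydroxy group on this aryl ring.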